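Series notes: vinyl for triazolylmethyl on the saturated chain

A few compounds are considered here, and "the series" means these few. Any claim that something is new, unique, unknown or untested is made for them only; others in the source may bear on it.

Compound 1 `Cn1ncc(Cl)c1-c1cc(C(=O)N[C@@H]2CN[C@H](CCn3cncn3)C[C@H]2c2ccc(Cl)c(Cl)c2)oc1Cl` is the reference point. In a functional assay on LNCaP cells (Homo sapiens) for antiproliferative activity (a higher number here means a weaker inhibitor, a lower number a stronger inhibitor), compound 1 gives 60 nM, the lowest of the two numbers measured in the set. Compound 2 `Cn1ncc(Cl)c1-c1cc(C(=O)N[C@@H]2CN[C@H](CC(=O)O)C[C@H]2c2ccc(Cl)c(Cl)c2)oc1Cl` differs from it in one place only; in this assay compound 2 gives 640 nM. The corresponding step of an 11-fold higher number from compound 1 to compound 2 (1.03 log units; beyond the scatter) is the only one available and runs toward weaker inhibition. Compound 3 `CC(=O)OCC[C@@H]1C[C@@H](c2ccc(F)c(F)c2)[C@H](NC(=O)c2cc(-c3c(Cl)cnn3C)c(Cl)o2)CN1` belongs to the series, but in this assay compound 3 gives "not determined" (no result reported), so it offers no anchor.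

Compound 4 `C=CC[C@@H]1C[C@@H](c2ccc(Cl)c(Cl)c2)[C@H](NC(=O)c2cc(-c3c(Cl)cnn3C)c(Cl)o2)CN1` is obtained from compound 1 by the change (vinyl in place of (1H-1,2,4-triazol-1-yl)methyl on a saturated chain carbon bound to a saturated ring carbon). The bearing step is an 11-fold higher number from compound 1 to compound 2 (1.03 log units; beyond the scatter), which shows that removing the (1H-1,2,4-triazol-1-yl)methyl at this position and replacing it with carboxy costs a large amount of potency. Vinyl is a different replacement, and no step in the set tests it directly, so the size of the carboxy step cannot simply be transferred. A loss is nonetheless the more likely direction.

Compound 4 is therefore expected to show a moderate step, a 3.0-fold higher number from compound 1 to compound 4 (0.48 log units; beyond the scatter), toward weaker inhibition in this assay. The estimate for compound 4 in this assay is 180 nM, with a range from 60 nM to 600 nM.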

Compound 4, half-maximal inhibitory concentration: 160 nM
Beside the measured number, compound 4's estimate is 1.1-fold (0.05 log units) above it; measured number inside the range.
By their numbers in this assay, from the lowest: compound 1; then compound 4; then compound 2.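

In this assay, the step of a 2.7-fold higher number from compound 1 to compound 4 (0.43 log units; beyond the scatter) shows that the (1H-1,2,4-triazol-1-yl)methyl group can give way at this place to vinyl, which has no ring and no hydrogen-bond acceptors, at only a modest cost. The step of a 4.0-fold lower number from compound 2 to compound 4 (0.60 log units; beyond the scatter) places vinyl clearly ahead of carboxy, so the large loss seen with carboxy cannot be read as the price of removing the (1H-1,2,4-triazol-1-yl)methyl group alone; it also depends on the group that enters. Across these three compounds, the number rises from compound 1 through compound 4 to compound 2, a ranking that covers only these three groups on this chain.

From the compounds shown here alone, whether a primary amine, a primary amide or a saturated alkyl chain of the same length as the allyl would sit with compound 4 or move toward either end of this ranking remains open. Going by these compounds, it is equally open whether another aromatic ring, such as imidazole or pyrazole, in place of the triazole would match compound 1 or lose potency. No measured evidence accounts for the differences among these groups.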